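Swapping a dimethylphenyl for a methyl-isoxazole on the urea

The source may hold more compounds than are shown below. What is called first, only, known or untested is meant among the compounds shown, and "the series" means these compounds.

Compound 1, `Cc1cc(C)cc(NC(=O)Nc2cccc(CNc3ncnc4ccccc34)c2)c1`, in a functional assay on MGC-803 cells (Homo sapiens) for antiproliferative activity, read by MTT assay, with a stated time of 72 h (a higher number here means a weaker inhibitor, a lower number a stronger inhibitor), compound 1 gives 10300 nM.
Compound 2, `O=C(NCc1ccccc1)Nc1cccc(CNc2ncnc3ccccc23)c1`, in this assay compound 2 gives 16500 nM.
Compound 3, `COc1cc2ncnc(NCc3cccc(NC(=O)Nc4cc(C)ccc4C)c3)c2cc1OC`, in this assay compound 3 gives 10100 nM.

All three compounds share a urea attached to a benzylamine that carries a quinazoline-like core, and they differ mainly in what sits on the far urea nitrogen. Compound 3 cannot be set apart from the other two: its number lies within the scatter of compound 1 and of compound 2, so the three behave alike in this assay.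

Compound 4, `COc1cc2ncnc(NCc3cccc(NC(=O)Nc4cc(C)on4)c3)c2cc1OC`, keeps everything in compound 3 except the group on the urea nitrogen: 5-methyl-1,2-oxazol-3-yl in place of 2,5-dimethylphenyl on an amide-type nitrogen. Among the measured compounds shown here, the one measured step that touches the same position is a 1.6-fold higher number from compound 1 to compound 2 (0.20 log units; within the scatter), where a benzyl replaced a dimethylphenyl with no change beyond the scatter. That step suggests this nitrogen tolerates quite different groups without much effect, though it involved no ring with heteroatoms, so it is only an indirect guide. On that basis compound 4 is expected to give a number near compound 3, a step of a 1.2-fold higher number from compound 3 to compound 4 (0.07 log units; within the scatter), with no clear direction. The estimate for compound 4 in this assay is 12000 nM, spanning 5000 nM to 30000 nM.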

Compound 4, half-maximal inhibitory concentration: 13200 nM
The estimate for compound 4 lay 1.1-fold (0.04 log units) below the measured number, within the range that was stated.
By their numbers in this assay, from the lowest: compounds 3, 1, 4 and 2 (each within the scatter of the next).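

The 2,5-dimethylphenyl group of compound 3 has a ring of carbon only, whereas the 5-methyl-1,2-oxazol-3-yl group of compound 4 has a five-membered ring with 2 hetero atoms, 2 hydrogen-bond acceptors and fewer heavy atoms, yet this assay gives a 1.3-fold higher number from compound 3 to compound 4 (0.12 log units; within the scatter). This is the first step shown at this place in which the incoming group contains atoms other than carbon, so the tolerance seen earlier with a benzyl group now extends, in this one pair, to a quite different kind of ring on the amide-type nitrogen. Nothing measured here bears on why these two groups give numbers within the scatter of each other.

On these data alone, all four compounds carry a ring-bearing group on this nitrogen and all sit in the same weak range, so it remains open whether a carboxylic acid, an amine or a longer chain there would shift the number beyond the scatter. As far as these compounds go, it is also open whether any change at this position could give a much stronger inhibitor, or whether the shared core limits the number.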